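The compounds below may be only part of what the source reports. "The series", "measured", "known", "first", "only" and "open" are said of these compounds alone.

In an ADME assay on microsomes from liver (Homo sapiens) for metabolic stability, read by LC-MS, using NADPH, with a stated time of 120 min, tested at 1 uM (a higher number here means that the compound lasts longer, a lower number that the compound disappears faster), two compounds have been measured so far. Compound 1 (`CCC(O)CNC(=O)C[C@H](CCC1CCCCC1)NC(=O)c1cc(-c2c(OC)cccc2OC)n(CC(C)C)n1`) gives a half-life of 0.0535 h, and compound 2 (`COC(=O)CN(C)C(=O)[C@H](CCc1ccccc1)NC(=O)c1cc(-c2c(OC)cccc2OC)n(CC(C)C)n1`) gives 0.136 h. That places compound 2 at the higher of the two numbers, with a gap to compound 1 that lies beyond the usual scatter. Both compounds disappear within a fraction of the incubation time.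

Compound 3 (`CCC(=O)CNC(=O)[C@H](CCc1ccccc1)NC(=O)c1cc(-c2c(OC)cccc2OC)n(CC(C)C)n1`) has yet to be measured. It differs from compound 2 in one place: (propanoylmethyl)amino in place of ((methoxycarbonyl)methyl)(methyl)amino on a carbonyl carbon. In words, (propanoylmethyl)amino stands in place of ((methoxycarbonyl)methyl)(methyl)amino on a carbonyl carbon.

Within the data shown here, no measured pair differs in only one place, so the data show no direct precedent for this change. The expectation in this assay therefore rests on the two values alone, and it is for no change beyond the scatter, with a slight lean towards compound 1 at 0.0535 h. The expected change, a 1.4-fold lower number from compound 2 to compound 3 (0.13 log units; within the scatter), is small and downward. For compound 3 the half-life is estimated at 0.1 h, within an expected range of 0.04 h to 0.25 h.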

Compound 3, half-life: 0.579 h
Compound 3: the middle estimate sits 5.8-fold (0.76 log units) below what was measured; measured number outside the range, above it.
By their numbers in this assay, from the lowest: compound 1; then compound 2; then compound 3.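

On the carbonyl carbon whose other neighbour is a saturated chain carbon, putting (propanoylmethyl)amino in place of ((methoxycarbonyl)methyl)(methyl)amino gives, in this assay, a 4.3-fold higher number from compound 2 to compound 3 (0.63 log units; beyond the scatter), so this position is not indifferent in this assay, and the step lies beyond the scatter. The change is not a single alteration: methoxycarbonyl gives way to propanoyl, and the entering group carries a hydrogen-bond donor, the amide hydrogen, where the leaving group has a methyl on that nitrogen. Nothing measured here says which feature of the change accounts for the longer half-life.

The compounds shown leave these two alterations tied together, so it stays open whether the gain would survive in a (propanoylmethyl)(methyl)amino group, which keeps the propanoyl and restores the methyl, or appear in a ((methoxycarbonyl)methyl)amino group, which keeps the methoxycarbonyl and carries the amide hydrogen. Also open, as far as these compounds go, is how a carboxylic acid or a secondary alcohol at the end of this chain, or a longer chain in place of propanoyl, would behave in this assay.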